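Swapping the Hydroxycarbamoyl End of Compound 2

This account rests on a few compounds, and the source may have more. Where it says the series, first, only, none or still open, it means among the compounds named here.

Compound 1 `Cn1cc(-c2cc(C(C)(C)O)ccc2OC2CC2)c2cc(C(=O)NCCCCCCC(=O)NO)[nH]c2c1=O` gives 5.5 nM in an assay on isolated protein for inhibition of protein deacetylase HDAC6 (Homo sapiens), read by fluorescence (on this read-out lower numbers stand for stronger inhibition and higher numbers for weaker inhibition), and compound 3 `Cn1cc(-c2cc(C(C)(C)O)ccc2OC2CC2)c2cc(C(=O)NCc3ccc(C(=O)NO)cc3)[nH]c2c1=O` gives 7.9 nM in the same test; the step of a 1.4-fold higher number from compound 1 to compound 3 (0.16 log units; within the scatter) therefore changes little. Compound 2 `Cn1cc(-c2ccccc2Oc2ccccc2)c2cc(C(=O)NCCCC(=O)NO)[nH]c2c1=O` gives 144 nM, the highest of the three numbers, and its distance to both compound 3 and compound 1 lies well beyond the scatter. Compound 4 `Cn1cc(-c2ccccc2Oc2ccccc2)c2cc(C(=O)NCCCCCC(=O)Nc3ccccc3N)[nH]c2c1=O` has not yet been measured. It differs from compound 2 by 2-((2-aminophenyl)carbamoyl)ethyl in place of hydroxycarbamoyl on a saturated chain carbon, three bonds along the chain from an amide-type nitrogen. Among the measured compounds shown here, no measured step covers an exchange of this kind: the one measured step, from compound 1 to compound 3, keeps the hydroxycarbamoyl group in place and alters only the part that carries it, so it gives no direct guide to what happens once that group is gone. Compound 4 is therefore estimated at 5000 nM, within a range from 800 nM to 30000 nM, which would be a step of a 35-fold higher number from compound 2 to compound 4 (1.54 log units; beyond the scatter).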

Compound 4, half-maximal inhibitory concentration: > 500 nM
Compound 4 gave a limit, no number; the forecaster's own chance of this, stated with the estimate: 30%; the middle value lies beyond the limit too.
By their numbers in this assay, from the lowest: compounds 1 and 3 (each within the scatter of the next); then compound 2. At a limit, above all of these: compound 4.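

Compound 4 gives no number, only a limit of the assay: the limit of > 500 nM in this assay, at which 1 of the 4 values shown sits. Even so, the step is an at least 3.4-fold higher number from compound 2 to compound 4 (0.54 log units; beyond the scatter), so putting 2-((2-aminophenyl)carbamoyl)ethyl in place of hydroxycarbamoyl at this chain end weakens inhibition by more than the scatter. Among the compounds shown here, all the earlier compounds kept hydroxycarbamoyl, so this is the first view of what happens once it is gone.

On these data alone, how weak compound 4 really is stays open. So does whether a carboxylic acid or a simple primary amide at this place would fare any better.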